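This account rests on a few compounds, and the source may have more. Where it says the series, first, only, none or still open, it means among the compounds named here.

In a functional assay on MV4-11 cells (Homo sapiens) for inhibition, read by resazurin assay, with a stated time of 72 h (on this read-out higher numbers stand for weaker inhibition of growth and lower numbers for stronger inhibition of growth), compound 2 `COc1ccc(Nc2nccc(-c3sc(SCc4cccnc4)nc3C)n2)c(OC)c1` gives 270 nM, the lowest of the three numbers at hand. In this assay compound 1 `COc1ccc(Nc2nccc(-c3cn(C4CCCC4)c4ccccc34)n2)c(OC)c1` gives 1740 nM, and compound 3 `CCCn1cc(-c2ccnc(Nc3ccc(OC)cc3OC)n2)c2ccccc21` gives 3620 nM. For the measured compounds named here, the one measured step, a 2.1-fold higher number from compound 1 to compound 3 (0.32 log units; beyond the scatter), concerns a different core and a different place than the change now followed, so it offers no direct guide. Compound 4 `COc1ccc(Nc2nccc(-c3sc(SCCCN(C)C)nc3C)n2)c(OC)c1` keeps the core of compound 2 and differs from it by 2-(dimethylamino)ethyl in place of pyridin-3-yl on a saturated chain carbon bound to a sulfur. Going by the values given here, no measured step bears on an exchange of this kind. The step is therefore expected to be a 1.1-fold higher number from compound 2 to compound 4 (0.05 log units; within the scatter), lying within the scatter. Compound 4 is estimated at 300 nM, with a range from 100 nM to 900 nM.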

Compound 4, concentration for 50% growth inhibition: 370 nM
Beside the measured number, compound 4's estimate is 1.2-fold (0.09 log units) below it; the measured number falls inside the stated range.
By their numbers in this assay, from the lowest: compounds 2 and 4 (each within the scatter of the next); then compound 1; then compound 3.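

In this assay, 2-(dimethylamino)ethyl in place of pyridin-3-yl on a saturated chain carbon bound to a sulfur gives a 1.4-fold higher number from compound 2 to compound 4 (0.14 log units; within the scatter), so at this place an open chain with no ring reads the same as the six-membered aromatic ring within the scatter. No earlier step touched this place, and nothing at hand accounts for the outcome. The compounds shown leave open how a carboxylic acid, a primary amine or a morpholine at the end of the chain would read, and how a shorter or longer chain would compare.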